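The compounds below may be only part of what the source reports. "The series", "measured", "known", "first", "only" and "open" are said of these compounds alone.

Compound 1 `COc1ccc(-c2cc(-c3cc(OC)c(OC)c(OC)c3)on2)cc1O`: 4000 nM
Compound 2 `COc1ccc(-c2cc(Cl)cnc2-c2cc(OC)c(OC)c(OC)c2)cc1O`: 800 nM

In a functional assay on HL-60 cells (Homo sapiens) (on this read-out higher numbers stand for an effect only at larger amounts of compound and lower numbers for an effect already at smaller amounts), compound 2 gives 800 nM, the lower of the two numbers, and compound 1 gives 4000 nM, a gap that lies beyond the usual scatter. Compound 3 `COc1ccc(-c2cccnc2-c2cc(OC)c(OC)c(OC)c2)cc1O` is not yet measured. It differs from compound 2 in one place: hydrogen in place of chloro on an aromatic carbon. Put simply, it has hydrogen in place of chloro on an aromatic carbon. Among the measured compounds shown here, no measured pair shows this change, so the expectation is uncertain. In this assay the expected change is a 1.5-fold higher number from compound 2 to compound 3 (0.18 log units; within the scatter), a small one towards a higher number, possibly no larger than the scatter. For compound 3 the estimated value is 1200 nM, with an expected range from 350 nM to 4500 nM.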

Compound 3, concentration for half-maximal activity: 600 nM
For compound 3 the middle estimate is 2.0-fold (0.30 log units) above the measured one; measured number inside the range.
By their numbers in this assay, from the lowest: compounds 3 and 2 (each within the scatter of the next); then compound 1.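

In this assay, putting hydrogen in place of chloro on this aromatic carbon gives a 1.3-fold lower number from compound 2 to compound 3 (0.12 log units; within the scatter). The chloro is therefore not required for the activity seen here, and losing this one heavy atom leaves the number within the usual scatter. Nothing available explains this result. On these data alone, this single pair shows only chloro and hydrogen at this position, so it remains open how an amine, a carboxylic acid or a longer chain on the same carbon would behave.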